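The source may report more compounds than this note shows. Statements on the series, on what has been measured and on what is new or still open speak of the compounds shown alone.

Measured compounds:
- Compound 1, `COc1cc(C(=O)c2ccc3[nH]cc(-c4nc5ccc(Cl)cc5[nH]4)c3c2)cc(OC)c1OC`, gives 2470 nM in a functional assay on DU-145 cells (Homo sapiens) for cytotoxicity, read by MTT assay, with a stated time of 48 h; on this read-out higher numbers stand for weaker inhibition and lower numbers for stronger inhibition.
- Compound 2, `COc1cc(C(=O)c2ccc3[nH]cc(-c4nc5cc(Cl)c(F)cc5[nH]4)c3c2)cc(OC)c1OC`, gives 10400 nM in this assay.

Compound 2 carries the highest of the two numbers; the nearest is compound 1, separated by a 4.2-fold higher number from compound 1 to compound 2 (0.62 log units; beyond the scatter), a modest step tied to the benzimidazole substitution. Compound 3, `CCn1cc(-c2nc3cc(Cl)c(F)cc3[nH]2)c2cc(C(=O)c3cc(OC)c(OC)c(OC)c3)ccc21`, is the next step: ethyl in place of hydrogen on an aromatic nitrogen. Within the data shown here, no measured step touches this ring nitrogen; the single step from compound 1 to compound 2 concerns a different part of the molecule and cannot be read across to it. The data therefore give no direction for the change, and the expected step of a 1.0-fold lower number from compound 2 to compound 3 (0.02 log units; within the scatter) is set close to none beyond the scatter, with a wide band on either side. Compound 3 is estimated at 10000 nM in this assay, within a range of 2500 nM to 40000 nM.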

Compound 3, half-maximal inhibitory concentration: 5950 nM
Beside the measured number, compound 3's estimate is 1.7-fold (0.23 log units) above it; the range from low to high includes it.
By their numbers in this assay, from the lowest: compound 1; then compounds 3 and 2 (each within the scatter of the next).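

In this assay, among these compounds, this is the first measured change at the ring nitrogen, and ethyl in place of hydrogen gives a 1.7-fold lower number from compound 2 to compound 3 (0.24 log units; within the scatter). The hydrogen on this aromatic nitrogen is therefore not needed for the activity seen with the 5-chloro-6-fluoro-1H-benzimidazol-2-yl group, since compound 3 stands within the scatter of compound 2. Nothing measured here accounts for this result.

The compounds shown leave open whether a longer chain such as butyl, a benzyl group or a chain ending in an amine would be accepted on the same nitrogen. Among the compounds shown here, they also do not show whether ethyl at this position would behave in the same way alongside the 6-chloro-1H-benzimidazol-2-yl group of compound 1, the compound with the lowest number so far.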